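A few compounds are considered here, and "the series" means these few. Any claim that something is new, unique, unknown or untested is made for them only; others in the source may bear on it.

Working notes on the series. Compound 1 `N/C(=N\NC(=S)N1CCOCC1)c1ccccn1` carries an unsubstituted pyridin-2-yl end; in a functional assay on A-375 cells (Homo sapiens) for cytotoxicity, read by MTT assay, with a stated time of 72 h, tested at 1 uM (on this read-out higher numbers stand for more inhibition of growth at the one concentration tested and lower numbers for less inhibition of growth), compound 1 gives 26.8%. Compound 2 `Cc1ccnc(/C(N)=N/NC(=S)N2CCOCC2)c1` adds a methyl to that ring, and in this assay compound 2 gives 43.2%. The step of a number 16.4 percentage points lower from compound 2 to compound 1 (beyond the scatter) corresponds to hydrogen in place of methyl on an aromatic carbon. Compound 3 `Cc1ccnc(/C(N)=N/NC(=S)N2CCN(c3ccccn3)CC2)c1` keeps the 4-methylpyridin-2-yl end of compound 2 but sits on a different core; the difference between the two cores is not broken down here. In this assay compound 3 gives 64.4%, the highest of the three measured values and beyond the scatter from both compound 2 and compound 1. Compound 4 `N/C(=N\NC(=S)N1CCN(c2ccccn2)CC1)c1ccccn1` is the analogue of compound 3 in which (hydrogen in place of methyl on an aromatic carbon). The place of this change reads the same as in the pair of compound 2 and compound 1, so it is the same change, now on the core of compound 3. With a single precedent on a different core, the expectation is loose. The step from compound 3 to compound 4 is expected to be a number 16.4 percentage points lower from compound 3 to compound 4 (beyond the scatter), resting on a number 16.4 percentage points lower from compound 2 to compound 1 (beyond the scatter). Compound 4 is therefore estimated at 48% in this assay, with a likely range from 34% to 62%.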

Compound 4, percent growth inhibition at one concentration: 70%
Compound 4: middle estimate off by 22 percentage points, on the low side, outside the stated range (above it).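

In this assay, hydrogen in place of methyl on the core of compound 3 gives a number 5.6 percentage points higher from compound 3 to compound 4 (within the scatter), so the 4-methylpyridin-2-yl to pyridin-2-yl change has no readable effect on this core. The size of the step seen on the core of compound 2 therefore does not carry over to the core of compound 3, and the two steps differ: the same change on two cores in this assay, a number 16.4 percentage points lower (beyond the scatter) from compound 2 to compound 1 and a number 5.6 percentage points higher (within the scatter) from compound 3 to compound 4, 22 percentage points apart, beyond the scatter of two such steps This shows that the change cannot be transferred as a fixed increment between these two cores, but with one pair per core it does not show which feature of the cores lies behind the difference, nor how the change would behave on any third core.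

The compounds shown leave open how an ethyl group, a methoxy group or an amine at this place on the ring would read on either core. Also open, from the compounds shown here alone, is whether the difference between the two steps would hold at concentrations other than the single one tested.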